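A few compounds are considered here, and "the series" means these few. Any claim that something is new, unique, unknown or untested is made for them only; others in the source may bear on it.

Measured compounds in the series:

- compound 1, `CN(CCN(C)C(=O)n1cc(C#N)cn1)Cc1ccc(OCc2ccccc2)cc1`: 320 nM
- compound 2, `CN(CCN(C)C(=O)n1cccn1)Cc1cccc(OCc2ccccc2)c1`: 5500 nM
- compound 3, `Cc1cnn(C(=O)N2CCN(C(c3ccc4ccccc4c3)c3ccc4ccccc4c3)CC2)c1`: > 100000 nM

In an assay on membranes from brain for binding affinity to Monoacylglycerol lipase ABHD6 (Mus musculus), read by fluorescence, with stated times of 1 h and 30 min (a lower number here means a stronger inhibitor, a higher number a weaker inhibitor), compound 1 gives 320 nM and compound 2 gives 5500 nM; the two differ in more than one place, so their values are noted side by side without a step between them. Compound 3 stands apart: its entry in this assay is a limit of the assay and not a number, > 100000 nM, as recorded under (the limit of > 100000 nM in this assay, at which 1 of the 3 values shown sits). Of the three values shown, only compound 3 sits at that limit.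

The next compound, compound 4, `N#Cc1cnn(C(=O)N2CCN(C(c3ccc4ccccc4c3)c3ccc4ccccc4c3)CC2)c1`, is derived from compound 3 by a single change: cyano in place of methyl on an aromatic carbon.

Going by the values given here, no measured pair in the set isolates this change, so the size of the step cannot be read from the data. Compound 1, which carries the cyano group, and compound 2, which carries none, are not a clean comparison. Because compound 3 already sits at > 100000 nM, the step from an at least 1.6-fold lower number from compound 3 to compound 4 (0.22 log units; that floor lies within the scatter) is expected to be modest in this assay, if any, and may still end at the limit. Compound 4 is estimated at 60000 nM, with a range from 10000 nM to 200000 nM.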

Compound 4, half-maximal inhibitory concentration: 560 nM
The estimate for compound 4 lay 110-fold (2.03 log units) above the measured number, outside the stated range (below it).
By their numbers in this assay, from the lowest: compounds 1 and 4 (each within the scatter of the next); then compound 2. At a limit, above all of these: compound 3.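

In this assay, going by these compounds alone, the exchange of 4-methyl-1H-pyrazol-1-yl for 4-cyano-1H-pyrazol-1-yl gives the first single-place comparison, an at least 170-fold lower number from compound 3 to compound 4 (2.25 log units; beyond the scatter), and it shows that this aromatic carbon is a sensitive position on the shared core. The rest of the structure is unchanged, so this one exchange separates a compound with a measured number from one without. The entry for compound 3 is a limit of the assay and not a number, so the step sets only a minimum size and the full size stays unknown: the limit of > 100000 nM in this assay, at which 1 of the 4 values shown sits.

The compounds shown leave open how a bare hydrogen, a chlorine atom or a primary carboxamide on this same carbon would read in this assay against methyl and cyano, and so whether the result is specific to the nitrile. Within the data shown here, they also leave open whether the same exchange would give a step of similar size on the core of compound 2, since the single step here comes from one core only.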